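Adding a Methoxy Group to Compound 1

The compounds below may be only part of what the source reports. "The series", "measured", "known", "first", "only" and "open" are said of these compounds alone.

Measured so far in an assay on FRT cells with Cystic fibrosis transmembrane conductance regulator variant F508del (Homo sapiens) as the target, read by fluorescence, with a stated time of 25 min; on this read-out higher numbers stand for an effect only at larger amounts of compound and lower numbers for an effect already at smaller amounts:
compound 1 `NC(=O)CN1CCN(c2nc(-c3ccccn3)nc3c2CN(Cc2ccccc2)CC3)CC1` gives 2800 nM
compound 2 `CN1CCN(CCCNc2nc(-c3ccccn3)nc3c2CN(Cc2ccccc2)CC3)CC1` gives 3100 nM
compound 3 `CN(C)CCN1CCN(c2nc(-c3ccccn3)nc3c2CN(Cc2ccccc2)CC3)CC1` gives 1500 nM

Among these three numbers compound 1 holds the second highest. Its nearest neighbour is compound 2, and the step of a 1.1-fold higher number from compound 1 to compound 2 (0.04 log units; within the scatter) lies within the scatter, so the two cannot be told apart. Its furthest neighbour is compound 3, yet even the step of a 1.9-fold lower number from compound 1 to compound 3 (0.27 log units; within the scatter) stays within the scatter. Going by the values given here, the only step that reaches beyond the scatter is a 2.1-fold lower number from compound 2 to compound 3 (0.32 log units; beyond the scatter), and it is a modest one.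

Compound 4 `COc1ccc(CN2CCc3nc(-c4ccccn4)nc(N4CCN(CC(N)=O)CC4)c3C2)cc1` differs from compound 1 in a single place: methoxy in place of hydrogen on an aromatic carbon. All three measured steps exchange groups on the other side of the shared core, the side carrying the piperazine or the amino chain; none of them touches the benzyl group. So there is no measured step that bears on this change, and the three measured compounds, whose numbers sit close together, offer no hint of a direction.

The expectation for compound 4 is therefore no step beyond the scatter, with a wider range than usual to allow for an untested position: no change at the digits printed from compound 1 to compound 4 (within the scatter). In this assay compound 4 is expected to give about 2800 nM, between 900 nM and 8500 nM.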

Compound 4, half-maximal effective concentration: 2300 nM
Compound 4: the middle estimate sits 1.2-fold (0.09 log units) above what was measured; measured number inside the range.
By their numbers in this assay, from the lowest: compounds 3, 4, 1 and 2 (each within the scatter of the next, the first and the last beyond it).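

This result gives the first reading from the benzyl side of the shared core, since every earlier step exchanged groups on the other side. In this assay, going from benzyl to 4-methoxybenzyl gives a 1.2-fold lower number from compound 1 to compound 4 (0.09 log units; within the scatter) and so the two compounds cannot be told apart, which shows that this spot on the aromatic ring can carry a methoxy group without a measurable penalty or gain. Nothing shown here accounts for this outcome, so it stands as a plain observation on one pair of compounds.

Still open, from the compounds shown here alone, is whether the same spot would stay just as indifferent to a different kind of group, such as an amine, a carboxylic acid or a longer chain ending in an alcohol, any of which could separate clearly from compound 1. Also open, going by these compounds, is whether methoxy would behave the same way elsewhere on that aromatic ring, or when paired with the side chains of compound 2 and compound 3, since one matched pair cannot settle either question.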